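Compound 3 to compound 4: methyl becomes nitro

The compounds below may be only part of what the source reports. "The series", "measured", "known", "first", "only" and "open" are said of these compounds alone.

Measured in a functional assay on PC-3 cells (Homo sapiens) for inhibition, read by MTT assay, with a stated time of 48 h; on this read-out higher numbers stand for weaker inhibition and lower numbers for stronger inhibition:
compound 1 `COc1ccc(/C=C2\SC(=O)N(CCNC(=O)Nc3c(C)n(C)n(-c4ccccc4)c3=O)C2=O)cc1` gives 13900 nM
compound 2 `COc1cc(/C=C2\SC(=O)N(CCNC(=O)Nc3c(C)n(C)n(-c4ccccc4)c3=O)C2=O)cc(OC)c1OC` gives 35400 nM
compound 3 `Cc1ccc(/C=C2\SC(=O)N(CC(=O)Nc3c(C)n(C)n(-c4ccccc4)c3=O)C2=O)cc1` gives 45300 nM

In this assay compound 3 , at 45300 nM, lies within the scatter of compound 2 and above compound 1 by more than the scatter. Compound 4 `Cc1c(NC(=O)CN2C(=O)S/C(=C\c3ccc([N+](=O)[O-])cc3)C2=O)c(=O)n(-c2ccccc2)n1C` differs from it by nitro in place of methyl on an aromatic carbon, a change from 4-methylphenyl to 4-nitrophenyl. Among the measured compounds shown here, no measured step involves nitro. The nearest evidence is a 2.5-fold higher number from compound 1 to compound 2 (0.41 log units; beyond the scatter), a modest step that also changes the aryl group, though on a different side chain. No step beyond the scatter is therefore expected, and the estimated step is a 1.2-fold lower number from compound 3 to compound 4 (0.08 log units; within the scatter). For compound 4 the expected value is 38000 nM, with an estimated range of 13000 nM to 100000 nM.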

Compound 4, half-maximal inhibitory concentration: > 100000 nM
Compound 4: only a limit was reported; the forecaster's own chance of this, stated with the estimate: 15%; middle value at least 2.6-fold (0.42 log units) from the limit.
By their numbers in this assay, from the lowest: compound 1; then compounds 2 and 3 (each within the scatter of the next). At a limit, above all of these: compound 4.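

In this assay, nitro in place of methyl on the aromatic carbon para to a large group gives an at least 2.2-fold higher number from compound 3 to compound 4 (0.34 log units; beyond the scatter). The earlier compounds shown here showed no change at this position on this side chain, and this one shows that the position is not indifferent, with the step running towards weaker inhibition. Compound 4 stands at a limit, so the full size of the step stays unknown: the limit of > 100000 nM in this assay, at which 1 of the 4 values shown sits.

As far as these compounds go, what an amine or a carboxylic acid at this position would give remains open. So does whether nitro would act the same way on the side chain of compound 1.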